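The source may hold more compounds than are shown below. What is called first, only, known or untested is meant among the compounds shown, and "the series" means these compounds.

Compound 1, `COc1cc(C(O)(C(F)(F)F)C(F)(F)F)cnc1N1CCN(S(=O)(=O)c2ccc(N)nc2)CC1`, a limit of < 14 mL.min-1.g-1 in an ADME assay (liver) for metabolic stability, with Liver microsome (Rattus norvegicus) as the target, using microsomes and NADPH, with a stated time of 30 min, tested at 1 uM; on this read-out higher numbers stand for fast clearance and lower numbers for slow clearance.
Compound 2, `CCn1cc(-c2cc(C(O)(C(F)(F)F)C(F)(F)F)cnc2N2CCN(S(=O)(=O)c3ccc(N)nc3)CC2)cn1`, 194 mL.min-1.g-1 in this assay.
Compound 3, `Nc1ccc(S(=O)(=O)N2CCN(c3ncc(C(O)(C(F)(F)F)C(F)(F)F)cc3-c3cnccc3F)CC2)cn1`, 22 mL.min-1.g-1 in this assay.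

Compound 1 gives only a limit, (the limit of < 14 mL.min-1.g-1 in this assay, at which 1 of the 3 values shown sits), and no number. Among the two numbers shown, compound 3 has the lowest, with compound 2 nearest at an 8.8-fold lower number from compound 2 to compound 3 (0.95 log units; beyond the scatter). The remaining step, an at least 13-fold higher number from compound 1 to compound 2 (1.14 log units; beyond the scatter), shows that the group on this aromatic carbon can move the read-out strongly, whereas an at least 1.5-fold higher number from compound 1 to compound 3 (0.19 log units; that floor lies within the scatter) shows a floor that stays within the scatter.

Compound 4, `Nc1ccc(S(=O)(=O)N2CCN(c3ncc(C(O)(C(F)(F)F)C(F)(F)F)cc3-c3cc4ccccc4s3)CC2)cn1`, differs from compound 3 in one place: 1-benzothiophen-2-yl in place of 4-fluoropyridin-3-yl on an aromatic carbon. No measured step involves a 1-benzothiophen-2-yl group, so the bearing of the shown steps is indirect. They show that exchanging one aromatic group for another at this position has produced both a modest change and a large one in this assay, so a change beyond the scatter is plausible in either direction, and the step from compound 1 to compound 2 shows the larger movement pointing upward. Compound 4 is therefore expected to give an upward step of a 5.0-fold higher number from compound 3 to compound 4 (0.70 log units; beyond the scatter). The estimated value of compound 4 in this assay is 110 mL.min-1.g-1, with a range from 35 mL.min-1.g-1 to 350 mL.min-1.g-1.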

Compound 4, intrinsic clearance in microsomes: 315 mL.min-1.g-1
Compound 4: the middle estimate sits 2.9-fold (0.46 log units) below what was measured; measured number inside the range.
By their numbers in this assay, from the lowest: compound 3; then compounds 2 and 4 (each within the scatter of the next). At a limit, below all of these: compound 1.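

In this assay, 1-benzothiophen-2-yl in place of 4-fluoropyridin-3-yl gives a 14-fold higher number from compound 3 to compound 4 (1.16 log units; beyond the scatter), so 1-ethyl-1H-pyrazol-4-yl is no longer the only aromatic group at this position to stand far above the 4-fluoropyridin-3-yl group, which among the aromatic groups shown is the one exception with a low number. The two high-lying groups differ in their rings and atoms, yet they cannot be told apart on this read-out, with a 1.6-fold higher number from compound 2 to compound 4 (0.21 log units; within the scatter), while the change from methoxy to 1-benzothiophen-2-yl gives an at least 22-fold higher number from compound 1 to compound 4 (1.35 log units; beyond the scatter). Compound 1 gives a limit and not a number, so that step is a floor: the limit of < 14 mL.min-1.g-1 in this assay, at which 1 of the 4 values shown sits.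

The compounds shown leave open which feature of the aromatic group sets the read-out, since ring size, ring count and hetero atoms change together across these four compounds. A pyridin-3-yl group without the fluorine, a plain phenyl or an amine on this aromatic carbon would show whether the fluorine in compound 3 or the ring itself accounts for its place apart from compound 2 and compound 4.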